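From 4-fluorophenyl to phenyl, starting at a limit

The compounds below may be only part of what the source reports. "The series", "measured", "known", "first", "only" and "open" are said of these compounds alone.

In an ADME assay on RAW264.7 cells (Mus musculus) for cytotoxicity, read by MTT assay, with a stated time of 48 h (a lower number here means a stronger inhibitor, a higher number a weaker inhibitor), compound 1 (`O=C(NCCOC(=S)Nc1ccc(F)cc1)c1cccnc1`) gives > 800000 nM, which is a limit and not a number. Compound 2 (`O=C(CCCCC1CCSS1)OCCCOC(=O)c1cccnc1`) gives > 800000 nM, also a limit. Together they show (the limit of > 800000 nM in this assay, at which 2 of the 2 values shown sit). Compound 3 (`O=C(NCCOC(=S)Nc1ccccc1)c1cccnc1`) has hydrogen in place of fluoro on an aromatic carbon of compound 1, para to a large group: hydrogen in place of fluoro on an aromatic carbon. Going by the values given here, no measured step covers this change, so no shift beyond the scatter is expected in this assay, in either direction. The expected step is a step that the limit leaves unreadable from compound 1 to compound 3. For compound 3 the estimated value is 1000000 nM, with an expected range of 500000 nM to 2000000 nM.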

Compound 3, half-maximal inhibitory concentration: > 800000 nM
Compound 3 was reported as a limit; the forecaster's own chance of this, stated with the estimate: 85%; the middle value is on the limit's open side.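

Compound 1 and compound 3 are both reported only as limits, so no step between them can be read: the limit of > 800000 nM in this assay, at which 3 of the 3 values shown sit.

The compounds shown leave open whether fluoro or hydrogen on this aromatic carbon makes any difference, and where the true value of each compound lies.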